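A few compounds are considered here, and "the series" means these few. Any claim that something is new, unique, unknown or untested is made for them only; others in the source may bear on it.

Measured compounds:
compound 1 `Cc1c(Cc2ccccc2)c(NNC(=O)Nc2cc(Cl)nc(Cl)c2)nc2c1cnn2C`, 21400 nM
compound 2 `CCN(CC)c1cc(NC(=O)NNc2cc(-c3ccc(F)cc3)c3cnn(C)c3n2)cc(Cl)n1`, 37000 nM
compound 3 `Cc1nn(C)c2nc(NNC(=O)Nc3cc(Cl)nc(Cl)c3)cc(-c3ccc(Cl)s3)c12`, 29400 nM

All three numbers come from a functional assay on SW620/5-FU cells (Homo sapiens) for cytotoxicity, read by MTT assay, with a stated time of 48 h, in the presence of a further agent that is not named here; on this read-out higher numbers stand for an effect only at larger amounts of compound and lower numbers for an effect already at smaller amounts. Compound 3 holds the middle value of the three, and its gap to compound 2 as well as its gap to compound 1 lies within the usual scatter, so the three compounds cannot be told apart on these numbers. Compound 4 `Cc1cc(NNC(=O)Nc2cc(Cl)nc(Cl)c2)nc2c1c(C)nn2C` is not yet measured. It differs from compound 3 in one place: methyl in place of 5-chlorothiophen-2-yl on an aromatic carbon. Among the measured compounds shown here, no step between measured compounds is available to size this change, so any expectation rests on the closeness of the three values alone. For compound 4 the expected value in this assay is 35000 nM, with a range from 14000 nM to 90000 nM. That estimate means a step of a 1.2-fold higher number from compound 3 to compound 4 (0.08 log units; within the scatter), expected to stay within the scatter.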

Compound 4, half-maximal effective concentration: > 100000 nM
Compound 4 gave a limit, no number; the forecaster's own chance of this, stated with the estimate: 20%; middle value at least 2.8-fold (0.45 log units) from the limit.
By their numbers in this assay, from the lowest: compounds 1, 3 and 2 (each within the scatter of the next). At a limit, above all of these: compound 4.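

In this assay, among the compounds shown here, methyl in place of 5-chlorothiophen-2-yl on this aromatic carbon gives an at least 3.4-fold higher number from compound 3 to compound 4 (0.53 log units; beyond the scatter), so the group here does affect the read-out, something the three earlier compounds, with no step between them, could not show. Compound 4 stands at a limit and not at a number, so the step has a lower bound but no known full size: the limit of > 100000 nM in this assay, at which 1 of the 4 values shown sits.

From the compounds shown here alone, whether the chlorine, the thiophene ring or only the larger group matters stays open. Plain thiophen-2-yl or an amine on this carbon could help to separate these possibilities.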